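The source may report more compounds than this note shows. Statements on the series, on what has been measured and on what is new or still open speak of the compounds shown alone.

Compound 1 `CC(C)C[C@H](N)c1cc(C(F)(F)F)ccc1N1CCN(C(=O)CCNC2CCCCC2)CC1` gives 4800 nM in an assay on HEK293 cells for displacement of a labelled ligand from Melanocortin receptor 4 (Homo sapiens); a higher number here means a weaker inhibitor, a lower number a stronger inhibitor. Compound 2 `CC(C)C[C@H](N)c1cc(C(F)(F)F)ccc1N1CCN(C(=O)CCC(=O)N(C)C)CC1` reaches only a limit of this assay, > 10000 nM. Compound 2 therefore stands at the weaker end of the two values shown, at the limit of > 10000 nM in this assay, at which 1 of the 2 values shown sits, and the step of an at least 2.0-fold higher number from compound 1 to compound 2 (0.31 log units; beyond the scatter) is at least modest.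

Compound 3 `CC(C)C[C@H](N)c1cc(C(F)(F)F)ccc1N1CCN(C(=O)COc2cccc3ccccc23)CC1` differs from compound 2 by (naphthalen-1-yl)oxy in place of (dimethylcarbamoyl)methyl on a saturated chain carbon bound to a carbonyl carbon. Among the compounds with values here, no measured step covers this change; the only one, an at least 2.0-fold higher number from compound 1 to compound 2 (0.31 log units; beyond the scatter), shows that the group at the chain end moves this assay at least modestly. Compound 3 is therefore expected near 3000 nM, within 700 nM to 12000 nM. That expected step is an at least 3.3-fold lower number from compound 2 to compound 3 (0.52 log units; beyond the scatter).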

Compound 3, inhibition constant: 2600 nM
Compound 3: the middle estimate sits 1.2-fold (0.06 log units) above what was measured; low and high end bracket the measured number.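

At the saturated chain carbon bound to a carbonyl carbon, (naphthalen-1-yl)oxy gives an at least 3.8-fold lower number from compound 2 to compound 3 (0.58 log units; beyond the scatter), so a chain end of two six-membered aromatic rings of carbon only still gives a measurable number in this assay. Compound 2 stands at a limit of the assay: the limit of > 10000 nM in this assay, at which 1 of the 3 values shown sits. Set against the cyclohexylamino end, the same group gives a 1.8-fold lower number from compound 1 to compound 3 (0.27 log units; within the scatter), so the chain-end nitrogen of compound 1 is not required to reach this range.

Open, on these data alone, is whether the two aromatic rings or the ether oxygen carry the difference. A phenoxy group or a (naphthalen-1-yl)methyl group at this carbon would separate the two.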